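Swapping the Imidazole Sulfonyl Arm for a Chloropyridine

The source may report more compounds than this note shows. Statements on the series, on what has been measured and on what is new or still open speak of the compounds shown alone.

Compound 1 `CC1CCN(C2CCN(S(=O)(=O)c3nccn3C)CC2)CC1` was examined in a functional assay on DLD-1 cells (Homo sapiens) for antiproliferative activity, read by CellTiter-Glo, with a stated time of 72 h; on this read-out higher numbers stand for weaker inhibition and lower numbers for stronger inhibition. In this assay compound 1 gives > 5000 nM, which is a limit of the assay rather than a number. Compound 2 `CC1CCN(C2CCN(S(=O)(=O)c3cccc(C(F)(F)F)c3)CC2)CC1` likewise gives > 5000 nM in this assay, again only a limit. Both values thus sit at the limit of > 5000 nM in this assay, at which 2 of the 2 values shown sit, so compound 1 cannot be ranked against compound 2 on these numbers. Compound 3 `CC1CCN(C2CCN(S(=O)(=O)c3ccc(Cl)nc3)CC2)CC1` differs from compound 1 by 6-chloropyridin-3-yl in place of 1-methyl-1H-imidazol-2-yl on a sulfonyl sulfur. Among the compounds with values here, with no measured step to draw on, no shift beyond the scatter is expected, and the step of a number no higher from compound 1 to compound 3 (the limit leaves the size open) is estimated as flat. Compound 3 is accordingly expected to give 5000 nM in this assay, within 1500 nM to 20000 nM, most likely once more as a limit.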

Compound 3, half-maximal inhibitory concentration: 3700 nM
Compound 3: the middle estimate sits 1.4-fold (0.13 log units) above what was measured; the measured number falls inside the stated range.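

In this assay, within the data shown here, compound 3 gives 3700 nM as the first value here that is a number and not a limit, so a group on this sulfonyl sulfur can bring the read-out into measurable range. The change to 6-chloropyridin-3-yl gives an at least 1.3-fold lower number from compound 1 to compound 3 (0.13 log units; that floor lies within the scatter) and this floor alone does not establish a real gain. The true size of the step stays open, since compound 1 gives only a limit: the limit of > 5000 nM in this assay, at which 2 of the 3 values shown sit.

From the compounds shown here alone, it remains open whether the chlorine or the pyridine nitrogen matters, and whether an amine or a methoxy group in place of the chlorine would move the number further.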